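A few compounds are considered here, and "the series" means these few. Any claim that something is new, unique, unknown or untested is made for them only; others in the source may bear on it.

Compound 1 `Cc1oc(-c2ccc(Cl)cc2)nc1CN1CCC(C(=O)NCCCN2C[C@H](C)C[C@H](C)C2)CC1` is examined in an ADME assay on microsomes from liver (Rattus norvegicus) for metabolic stability, read by LC-MS, using NADPH, at 37 degrees C; on this read-out lower numbers stand for a shorter-lived compound and higher numbers for a longer-lived compound. In this assay compound 1 gives > 0.5 h, which is a limit of the assay and not a number. Compound 3 `CCCN(CCC)CCNC(=O)C1CCN(Cc2nc(-c3ccccc3C)oc2C)CC1` likewise gives > 0.5 h in this assay, again a limit. Compound 2 `Cc1ccccc1-c1nc(CN2CCC(C(=O)NCCCCN3C[C@H](C)C[C@H](C)C3)CC2)c(C)o1` gives 0.2 h in this assay. Going by the values given here, the single measured step, an at least 2.5-fold higher number from compound 2 to compound 3 (0.39 log units; beyond the scatter), concerns the dipropylamino end of the chain and not the 4-chlorophenyl group. Compound 4 `COc1cccc(F)c1-c1nc(CN2CCC(C(=O)NCCCN3C[C@H](C)C[C@H](C)C3)CC2)c(C)o1` differs from compound 1 by 2-fluoro-6-methoxyphenyl in place of 4-chlorophenyl on an aromatic carbon. Among the compounds with values here, no measured step touches that change, so no shift beyond the scatter is expected, and the reading of compound 1 rests on (the limit of > 0.5 h in this assay, at which 2 of the 3 values shown sit). Compound 4 is therefore expected to give about 0.6 h, within 0.3 h to 1.5 h. The estimated step is a step that the limit leaves unreadable from compound 1 to compound 4.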

Compound 4, half-life: 0.143 h
The estimate for compound 4 lay 4.2-fold (0.62 log units) above the measured number, outside the stated range (below it).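

In this assay, replacing 4-chlorophenyl with 2-fluoro-6-methoxyphenyl gives an at least 3.4-fold lower number from compound 1 to compound 4 (0.54 log units; beyond the scatter). Going by these compounds alone, the only earlier step concerned the amine end of the chain, so this is the first sign that the aromatic group on the five-membered ring can also move the half-life beyond the scatter, with the rest of the molecule unchanged. The true size of this step remains unknown, as it starts from a limit: the limit of > 0.5 h in this assay, at which 2 of the 4 values shown sit.

The compounds shown leave open whether the fluoro or the methoxy group accounts for the drop. A simple 2-methoxyphenyl or 2-fluorophenyl group at this place would separate the two.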